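A methyl for a fluoro, with no measured starting point

The source may hold more compounds than are shown below. What is called first, only, known or untested is meant among the compounds shown, and "the series" means these compounds.

Among the measured compounds shown here, in a functional assay on A2780 cells (Homo sapiens) for antiproliferative activity (on this read-out lower numbers stand for stronger inhibition and higher numbers for weaker inhibition), compound 1 (`Cc1ccc2c(c1C)CN(C(=O)N(C)C)CC2c1cccc(O)c1`) gives 376 nM as the only number in this small set. Compound 2 (`CN(C)C(=O)N1Cc2c(F)cccc2C(c2cccc(O)c2)C1`) offers no such anchor: for compound 2 the record reads "not determined" (no result reported) and so gives no potency to start from. Compound 3 (`Cc1cccc2c1CN(C(=O)N(C)C)CC2c1cccc(O)c1`) follows from compound 2 through a single structural change, (methyl in place of fluoro on an aromatic carbon), which is methyl in place of fluoro on an aromatic carbon.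

For the measured compounds named here, no step between two measured compounds is available to show how much such a swap matters, and the data contain no direct measure of it. In this assay the expectation is therefore for no shift beyond the usual scatter from the one measured level, that of compound 1 at 376 nM, and no direction is favoured with any confidence. The estimate is deliberately wide, since it rests on one number. Compound 3 is expected to read about 450 nM with an estimated span from 150 nM to 1300 nM as the likely range.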

Compound 3, half-maximal inhibitory concentration: 2050 nM
Beside the measured number, compound 3's estimate is 4.6-fold (0.66 log units) below it; the measured number lies above the stated range.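

In this assay, among the compounds shown here, hydrogen in place of methyl on an aromatic carbon brings a 5.5-fold higher number from compound 1 to compound 3 (0.74 log units; beyond the scatter), which is the first measured step in this set. For the compounds shown here, it shows that this ring of the shared core is sensitive to a change of a single heavy atom: the one methyl kept in compound 3 does not hold the level of compound 1, and the read-out moves beyond the scatter toward weaker inhibition. The result says nothing directly about methyl in place of fluoro, as the step from compound 2 to compound 3 cannot be read, compound 2 having no number to compare. Nothing in the available data accounts for the loss of potency.

The compounds shown leave open whether fluoro or methyl reads better on this aromatic carbon, and whether the methyl kept in compound 3 adds anything over hydrogen. They also leave open how a chloro, a methoxy or an amine would read on this aromatic carbon, so the trend rests on this single pair.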